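This account rests on a few compounds, and the source may have more. Where it says the series, first, only, none or still open, it means among the compounds named here.

In a functional assay for agonist activity at G protein-coupled receptor 88 (Homo sapiens), read by HTRF and cAMP accumulation (on this read-out higher numbers stand for an effect only at larger amounts of compound and lower numbers for an effect already at smaller amounts), compound 3 `CC[C@H](C)[C@H](N)CN(C(=O)[C@@H]1C[C@H]1c1ccccc1F)c1ccc(-c2ccccc2)cc1` gives 650 nM, the lowest of the three numbers recorded. Compound 1 `CC[C@H](C)[C@H](N)CN(C(=O)[C@@H]1C[C@H]1c1ccc(Cl)cc1)c1ccc(-c2ccccc2)cc1` gives 4300 nM in this assay, and compound 2 `CC[C@H](C)[C@H](N)CN(C(=O)[C@@H]1C[C@H]1c1cccc(Cl)c1)c1ccc(-c2ccccc2)cc1` gives 2200 nM. The step of a 2.0-fold lower number from compound 1 to compound 2 (0.29 log units; within the scatter) lies within the scatter, whereas the steps of a 6.6-fold lower number from compound 1 to compound 3 (0.82 log units; beyond the scatter) and a 3.4-fold lower number from compound 2 to compound 3 (0.53 log units; beyond the scatter) stand beyond it, so compound 3 is set apart from both companions. Compound 4 `CC[C@H](C)[C@H](N)CN(C(=O)[C@@H]1C[C@H]1c1ccc(F)cc1F)c1ccc(-c2ccccc2)cc1` differs from compound 3 by fluoro in place of hydrogen on an aromatic carbon. Within the data shown here, none of the measured steps adds a second halogen to this ring; each moves a single halogen from one aromatic carbon to another. The nearest guide is that compound 1, which bears a 4-chlorophenyl, sits furthest from compound 3, though a chloro is not a fluoro and the 2-fluorophenyl pattern of compound 3 is kept in compound 4. The step of a 1.4-fold higher number from compound 3 to compound 4 (0.14 log units; within the scatter) is therefore expected to be small, most likely within the scatter, with a slight lean toward a higher number. Compound 4 is estimated at 900 nM in this assay, within a range from 350 nM to 2500 nM.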

Compound 4, half-maximal effective concentration: 1300 nM
The estimate for compound 4 lay 1.4-fold (0.16 log units) below the measured number; measured number inside the range.
By their numbers in this assay, from the lowest: compounds 3, 4, 2 and 1 (each within the scatter of the next, the first and the last beyond it).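

In this assay, the fluoro on the aromatic carbon meta to a fluoro group and para to a large group is the first change shown that adds a halogen to this ring rather than moving one, and the step stays within the scatter: a 2.0-fold higher number from compound 3 to compound 4 (0.30 log units; within the scatter). The 2,4-difluorophenyl also stays within the scatter of the 3-chlorophenyl, a 1.7-fold lower number from compound 2 to compound 4 (0.23 log units; within the scatter), but stands apart from the 4-chlorophenyl, a 3.3-fold lower number from compound 1 to compound 4 (0.52 log units; beyond the scatter), so a halogen para to the large group does not by itself place compound 4 with compound 1. Nothing given here accounts for these steps.

Open, from the compounds shown here alone, is what a chloro, a methoxy or a trifluoromethyl on this carbon would do with the first fluoro kept. Also open, going by these compounds, is what a 4-fluorophenyl without that first fluoro would give.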